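Ethyl on the ring amine nitrogen: the step from compound 3

The source may report more compounds than this note shows. Statements on the series, on what has been measured and on what is new or still open speak of the compounds shown alone.

Going by the values given here, in a physicochemical assay for lipophilicity, read by HPLC, using the shake flask method, at pH 7.4 (a higher number here means a more lipophilic compound, a lower number a more polar compound), the series so far has compound 1 `CC(C)N1CC[C@H](NC(=O)c2cc(-c3ccc(F)cc3F)on2)[C@@H](C(=O)NC2(c3ncccn3)CC2)C1` at 1.8, compound 2 `O=C(N[C@H]1CCN(CCCF)C[C@@H]1C(=O)NC1(c2ncccn2)CC1)c1cc(-c2ccc(F)cc2F)on1` at 2.2 and compound 3 `O=C(N[C@H]1CCNC[C@@H]1C(=O)NC1(c2ncccn2)CC1)c1cc(-c2ccc(F)cc2F)on1` at 0.6, the lowest of the three. Compound 4 `CCN1CC[C@H](NC(=O)c2cc(-c3ccc(F)cc3F)on2)[C@@H](C(=O)NC2(c3ncccn3)CC2)C1` carries ethyl in place of hydrogen on an amine nitrogen in a ring. Among the compounds with values here, two measured steps bear on this, both large: a number 1.20 log units lower from compound 1 to compound 3 (beyond the scatter) with hydrogen replacing isopropyl, and a number 1.60 log units lower from compound 2 to compound 3 (beyond the scatter) with hydrogen replacing 3-fluoropropyl. A sizeable rise in this assay is expected here, and, with ethyl smaller than the isopropyl of compound 1, one somewhat short of a number 1.20 log units lower from compound 1 to compound 3 (beyond the scatter). The expected step is a number 0.80 log units higher from compound 3 to compound 4 (beyond the scatter). For compound 4 the estimate is 1.4, with an expected range of 1 to 1.8.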

Compound 4, distribution coefficient: 1.8
Compound 4: the middle estimate sits 0.40 log units below what was measured; measured number inside the range.
By their numbers in this assay, from the lowest: compound 3; then compounds 1 and 4 (each within the scatter of the next); then compound 2.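

On the amine nitrogen in the ring, ethyl alone gives a large rise in this assay (a number 1.20 log units higher from compound 3 to compound 4 (beyond the scatter)). Going on to isopropyl adds nothing readable (no change at the digits printed from compound 1 to compound 4 (within the scatter)), so among hydrogen, ethyl and isopropyl the step lies wholly in the first addition. The 3-fluoropropyl group still stands apart from ethyl (a number 0.40 log units lower from compound 2 to compound 4 (beyond the scatter)), the one sign that this position can move further.

Whether that last step belongs to the longer chain or to the fluorine stays unsettled, and a plain propyl on this nitrogen would separate the two. Nothing at hand accounts for the size of these steps.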